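Working notes: amine end of the side chain

The source may report more compounds than this note shows. Statements on the series, on what has been measured and on what is new or still open speak of the compounds shown alone.

So far, in a functional assay on HCT-8 cells (Homo sapiens) for antiproliferative activity, read by MTT assay, with a stated time of 48 h (on this read-out higher numbers stand for weaker inhibition and lower numbers for stronger inhibition), the series reads as follows:
Compound 1 `C=C(c1ccc(OC)cc1NC(=O)CNC)c1ccc(OC)c2c1C=CC(C)(C)O2` gives 980 nM
Compound 2 `C=C(c1ccc(OC)cc1NC(=O)CNCC)c1ccc(OC)c2c1C=CC(C)(C)O2` gives 3050 nM

Of these two, compound 2 carries the highest number. Among the compounds with values here, the only measured step is a 3.1-fold higher number from compound 1 to compound 2 (0.49 log units; beyond the scatter) and counts as modest. The change to compound 3 `C=C(c1ccc(OC)cc1NC(=O)CN(C)C)c1ccc(OC)c2c1C=CC(C)(C)O2` is dimethylamino in place of ethylamino on a saturated chain carbon bound to a carbonyl carbon and amounts to dimethylamino in place of ethylamino on a saturated chain carbon bound to a carbonyl carbon. Within the data shown here, compound 2 and compound 3 have the same atoms, joined differently, and no step of that kind has been measured, so the one available step is only a partial guide. A modest move to a lower number is expected in this assay and the size of a 3.1-fold higher number from compound 1 to compound 2 (0.49 log units; beyond the scatter) sets its likely ceiling. The expected step is a 1.8-fold lower number from compound 2 to compound 3 (0.25 log units; within the scatter) as an estimate. Compound 3 is estimated at 1700 nM with an expected range of 700 nM to 4000 nM for now.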

Compound 3, half-maximal inhibitory concentration: 1920 nM
Estimate against measurement, compound 3: 1.1-fold (0.05 log units) below; the range from low to high includes it.
By their numbers in this assay, from the lowest: compounds 1, 3 and 2 (each within the scatter of the next, the first and the last beyond it).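

In this assay, moving the same atoms from ethylamino to dimethylamino on a saturated chain carbon bound to a carbonyl carbon gives a 1.6-fold lower number from compound 2 to compound 3 (0.20 log units; within the scatter). Methyl in place of hydrogen on an amine nitrogen gives a 2.0-fold higher number from compound 1 to compound 3 (0.29 log units; within the scatter), so this added methyl, unlike the one that turns compound 1 into compound 2, does not clear the scatter, and compound 3 cannot be told apart from either neighbour. No supporting measurement bears on these steps.

Still open, from the compounds shown here alone, is how this amine end behaves with a primary amino group, a diethylamino group or a piperidine ring in its place. A longer chain between the carbonyl and the amine nitrogen is equally unresolved.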